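Swapping 3-methylphenyl for 3,4-dichlorophenyl on the aryl ether oxygen

The source may hold more compounds than are shown below. What is called first, only, known or untested is meant among the compounds shown, and "the series" means these compounds.

Measured so far:
Compound 1, `N[C@@H](COP(=O)(O)OCCCOC(=O)CCc1ccccc1OCc1cccc(OC2CCCCC2)c1)C(=O)O`: 18.8% in an assay on cells for agonist activity at probable G-protein coupled receptor 34 (Mus musculus), with a stated time of 1 h; on this read-out higher numbers stand for larger maximal responses and lower numbers for smaller maximal responses
Compound 2, `Cc1cccc(Oc2cccc(COc3ccccc3CCC(=O)OCCCOP(=O)(O)OC[C@H](N)C(=O)O)c2)c1`: 21.3% in this assay

Both measured compounds share the same core and differ only in the group on the oxygen on the aromatic ring. For the measured compounds named here, the one measured step, a number 2.5 percentage points higher from compound 1 to compound 2 (within the scatter), is within the scatter, so compound 2 and compound 1 give numbers that cannot be told apart on this read-out; compound 2 merely gives the nominally higher of the two.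

Compound 3, `N[C@@H](COP(=O)(O)OCCCOC(=O)CCc1ccccc1OCc1cccc(Oc2ccc(Cl)c(Cl)c2)c1)C(=O)O`, is not yet measured. It differs from compound 2 in one place: 3,4-dichlorophenyl in place of 3-methylphenyl on an oxygen on an aromatic ring.

Going by the values given here, the only step that bears on this change is the one from compound 1 to compound 2, which exchanged one group on the same oxygen for another and stayed within the scatter. Among the compounds with values here, no measured compound carries chlorine on this ring, so nothing speaks for a step of either sign. The expectation for compound 3 is therefore a step of a number 0.7 percentage points higher from compound 2 to compound 3 (within the scatter) in this assay, not beyond the scatter. Compound 3 is accordingly estimated at 22%, with a range from 11% to 36%.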

Compound 3, largest response reached (Emax), in percent of the reference or control that the assay uses: 18%
The estimate for compound 3 lay 4 percentage points above the measured number; the measured number falls inside the stated range.
By their numbers in this assay, from the lowest: compounds 3, 1 and 2 (each within the scatter of the next).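

In this assay, putting 3,4-dichlorophenyl on the oxygen gives a number 3.3 percentage points lower from compound 2 to compound 3 (within the scatter), and the comparison with the cyclohexyl compound gives a number 0.8 percentage points lower from compound 1 to compound 3 (within the scatter). Cyclohexyl, 3-methylphenyl and 3,4-dichlorophenyl on this oxygen therefore cannot be told apart on this read-out, and this now holds for a group carrying chlorine as well as for the two earlier groups, so the series so far shows no dependence of the maximal response on which of these three groups sits at this position. Nothing at hand explains why the three numbers cannot be separated.

From the compounds shown here alone, whether any group on this oxygen can move the number beyond the scatter remains open; a carboxylic acid, an amine or a plain methyl in place of 3,4-dichlorophenyl would be a much larger change than the three groups compared here. The compounds shown also differ only at this one oxygen, so they leave open whether a change elsewhere on the shared core, such as a longer chain, would move the maximal response.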